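Swapping a hydroxy for a chloro on the indole core

This account rests on a few compounds, and the source may have more. Where it says the series, first, only, none or still open, it means among the compounds named here.

Compound 1 `COc1ccccc1N1CCN(CCCNC(=O)Cc2c[nH]c3ccccc23)CC1`: 5.25 nM
Compound 2 `COc1ccccc1N1CCN(CCCNC(=O)c2cc3cc(O)ccc3[nH]2)CC1`: 26.9 nM
Compound 3 `COc1ccccc1N1CCN(CCCNC(=O)c2cc3cccc([N+](=O)[O-])c3[nH]2)CC1`: 28.2 nM

In an assay on isolated protein (thoracic aorta, strain Sprague-Dawley) for antagonist activity at Alpha-1D adrenergic receptor (Rattus norvegicus), with a stated time of 20 min (a higher number here means weaker binding, a lower number tighter binding), compound 2 gives the second highest of the three numbers. Within the data shown here, compound 3 gives a number within the scatter of it, and compound 1 gives a lower one: the step of a 5.1-fold higher number from compound 1 to compound 2 (0.71 log units; beyond the scatter) is the only single change measured here. Compound 4 `COc1ccccc1N1CCN(CCCNC(=O)c2cc3cc(Cl)ccc3[nH]2)CC1` differs from compound 2 by chloro in place of hydroxy on an aromatic carbon. Among the measured compounds shown here, no measured step changes this very position, so the measured step does not bear directly on it; compound 2 and compound 3 only show that two differently substituted versions of the shared core land close together. A small step either way, or none beyond the scatter, is therefore expected, a 1.3-fold lower number from compound 2 to compound 4 (0.13 log units; within the scatter). Compound 4 is estimated at 20 nM, between 6 nM and 65 nM.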

Compound 4, dissociation constant: 19.5 nM
Beside the measured number, compound 4's estimate is 1.0-fold (0.01 log units) above it; the measured number falls inside the stated range.
By their numbers in this assay, from the lowest: compound 1; then compounds 4, 2 and 3 (each within the scatter of the next).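

Replacing hydroxy, with its hydrogen-bond donor and acceptor, by chloro, with neither, leaves this assay within the scatter (a 1.4-fold lower number from compound 2 to compound 4 (0.14 log units; within the scatter)), so in this pair the number does not depend on those hydroxy features. The chloro compound still shows the gap to the other side chain, with a 3.7-fold higher number from compound 1 to compound 4 (0.57 log units; beyond the scatter) beyond the scatter. Nothing available explains why the swap changes so little.

On these data alone, whether an amine or a carboxylic acid at this position would also stay within the scatter remains open.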